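Propyl for Isopropyl on a Weak Antiproliferative Series

The compounds below may be only part of what the source reports. "The series", "measured", "known", "first", "only" and "open" are said of these compounds alone.

Measured compounds:
Compound 1 `CC[C@@H]1C(=O)N(C)c2cnc(-n3ccc4cc(F)ccc43)nc2N1C1CCCC1`: "not active" (no number reported)
Compound 2 `CCC1C(=O)N(C)c2cnc(Nc3ccc(S(=O)(=O)NCCO)cc3)nc2N1c1ccn(C)n1`: "not active" (no number reported)
Compound 3 `CCC1C(=O)N(C)c2cnc(-n3ccc4cc(C(=O)NCC(C)C)ccc43)nc2N1c1ccn(C)n1`: 19200 nM

Among the measured compounds shown here, in a functional assay on A549 cells (Homo sapiens) for antiproliferative activity, read by CCK-8 assay, with a stated time of 72 h (a lower number here means a stronger inhibitor of growth, a higher number a weaker inhibitor of growth), compound 3 gives 19200 nM, the only number recorded among the three. Compound 1 and compound 2 carry no figure in this assay, so compound 3 stands alone as the sole anchor. Compound 4 `CCCCNC(=O)c1ccc2c(ccn2-c2ncc3c(n2)N(c2ccn(C)n2)C(CC)C(=O)N3C)c1` has the same atoms as compound 3, joined differently: propyl in place of isopropyl on a saturated chain carbon bound to an amide-type nitrogen. For the measured compounds named here, no pair of measured compounds tracks this kind of change, so its size cannot be read from the data. With a single anchor and a rearrangement of the same chain, the step of a 1.1-fold lower number from compound 3 to compound 4 (0.03 log units; within the scatter) is expected to stay within the usual scatter, in no particular direction. Compound 4 is therefore estimated at 18000 nM, with a range from 6000 nM to 50000 nM.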

Compound 4, concentration for 50% growth inhibition: 37300 nM
The estimate for compound 4 lay 2.1-fold (0.32 log units) below the measured number, within the range that was stated.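

In this assay, among the compounds shown here, the step of a 1.9-fold higher number from compound 3 to compound 4 (0.29 log units; within the scatter) gives the first measured reading for propyl in place of isopropyl on a saturated chain carbon bound to an amide-type nitrogen. It lies within the scatter, so this rearrangement of the chain shows no measurable effect on growth inhibition here. No measured data bear on why this is so.

The compounds shown leave open whether a longer chain such as hexyl, a cyclopropyl ring or a terminal amine at this place would move the number beyond the scatter.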